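Small Methyl Changes and Cytotoxicity in Cultured Cells

This account rests on a few compounds, and the source may have more. Where it says the series, first, only, none or still open, it means among the compounds named here.

Compound 1 `CCCCNc1nc(N)nc2ccn(Cc3ccccn3)c12` was tested in an ADME assay on HEK293 cells (Homo sapiens) for cytotoxicity, read by ATP content, with a stated time of 6 h; on this read-out lower numbers stand for higher toxicity in this test and higher numbers for lower toxicity in this test. In this assay compound 1 gives > 24000 nM, a limit of the assay rather than a number. Compound 2 `CCCCNc1nc(N)nc2ccn(Cc3cccc(C)n3)c12` carries methyl in place of hydrogen on an aromatic carbon. In this assay compound 2 gives > 24000 nM, again a limit. Compound 3 `Nc1nc(NCc2ncco2)c2c(ccn2Cc2ccccn2)n1` differs from compound 1 by 1,3-oxazol-2-yl in place of propyl on a saturated chain carbon bound to a nitrogen on an aromatic ring. In this assay compound 3 gives > 24000 nM, also a limit. Neither step, a step that the two limits leave unreadable from compound 1 to compound 2 nor a step that the two limits leave unreadable from compound 1 to compound 3, can be sized, since all three values sit at the limit of > 24000 nM in this assay, at which 3 of the 3 values shown sit. Compound 4 `Cc1cnc(CNc2nc(N)nc3ccn(Cc4ccccn4)c23)o1` is not yet measured; it carries methyl in place of hydrogen on an aromatic carbon. This is the same kind of change as from compound 1 to compound 2, but its place is a five-membered aromatic ring with 1 nitrogen and 1 oxygen, next to the ring oxygen, rather than a six-membered aromatic ring with 1 nitrogen, next to the ring nitrogen. Compound 4 is expected to stay at the limit, a step that the limit leaves unreadable from compound 3 to compound 4, resting on compound 3 sitting at the limit of > 24000 nM in this assay, at which 3 of the 3 values shown sit. The estimate for compound 4 is 30000 nM, from 15000 nM to 100000 nM.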

Compound 4, half-maximal cytotoxic concentration: > 24000 nM
Compound 4: a limit, no number (the forecaster's own chance of this, stated with the estimate: 85%); the middle value lies beyond the limit too.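

For the compounds shown here, compound 4, like compound 1 and compound 3, gives only a limit, so no step to compound 4 from either can be read: the limit of > 24000 nM in this assay, at which 4 of the 4 values shown sit.

Going by these compounds, whether any of these changes alters the result in this assay stays open: none of the four compounds gives a number.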